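Ring-nitrogen substituent swap on the shared core

The compounds below may be only part of what the source reports. "The series", "measured", "known", "first", "only" and "open" are said of these compounds alone.

Measured so far:
compound 1 `CCOC(=O)C1=Cc2ccccc2OC1(OCc1cn(CC(=O)Nc2ccccc2Br)nn1)C(F)(F)F` — > 150000 nM
compound 2 `COc1ccc(-c2cc(COC3(C(F)(F)F)Oc4ccccc4C=C3C(=O)O)on2)cc1` — 36200 nM

In a functional assay on A549 cells (Homo sapiens) for inhibition, read by MTT assay, with a stated time of 24 h (a lower number here means a stronger inhibitor, a higher number a weaker inhibitor), compound 1 reaches only a limit, > 150000 nM, so no number is known for it. In this assay, among the compounds with values here, compound 2 gives 36200 nM, the one value in the set that is a number. Within the data shown here, compound 1 therefore stands at the weak end of what has been measured, resting on the limit of > 150000 nM in this assay, at which 1 of the 2 values shown sits, rather than on a value; no step between measured compounds links it to compound 2, and the two values show only that compound 2 is within the measured range while compound 1 is not.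

Compound 3 `CCOC(=O)C1=Cc2ccccc2OC1(OCc1cn(-c2cccc(OC)c2)nn1)C(F)(F)F` is the next compound, differing from compound 1 in a single place: 3-methoxyphenyl in place of ((2-bromophenyl)carbamoyl)methyl on an aromatic nitrogen.

Among the measured compounds shown here, with compound 1 held only as a limit, no measured step sets the size of this change. The expectation is a modest move toward a measurable value, as in an at least 1.6-fold lower number from compound 1 to compound 3 (0.22 log units; that floor lies within the scatter), with a fair chance that compound 3 again returns only a limit. For compound 3 the estimate in this assay is 90000 nM, expected between 25000 nM and 300000 nM.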

Compound 3, half-maximal inhibitory concentration: > 150000 nM
Compound 3 ended at the assay's limit; the forecaster's own chance of this, stated with the estimate: 45%; middle value at least 1.6-fold (0.22 log units) from the limit.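

Compound 1 and compound 3 both end as limits in this assay, so no size can be read for the step between them: the limit of > 150000 nM in this assay, at which 2 of the 3 values shown sit.

The compounds shown leave open whether 3-methoxyphenyl in place of ((2-bromophenyl)carbamoyl)methyl on an aromatic nitrogen changes the value at all, and in which direction.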